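Adding methoxy to the phenoxy group of compound 2

The source may report more compounds than this note shows. Statements on the series, on what has been measured and on what is new or still open speak of the compounds shown alone.

Measured in a functional assay on ileum (Cavia porcellus) for antagonist activity, with a stated time of 30 s (on this read-out higher numbers stand for weaker inhibition and lower numbers for stronger inhibition), so far:
compound 1 `O=C(O)c1cc(=O)c2c(OCCCOc3ccccc3)cccc2o1` gives 35 ug/mL
compound 2 `O=C(O)c1cc(=O)c2ccc(OCCCCCOc3ccccc3)cc2o1` gives 0.4 ug/mL

In this assay compound 2 has the lower of the two numbers, and its gap to compound 1 lies beyond the scatter. Compound 3 `COc1cccc(OCCCCCOc2ccc3c(=O)cc(C(=O)O)oc3c2)c1` differs from compound 2 by methoxy in place of hydrogen on an aromatic carbon as methoxy in place of hydrogen on an aromatic carbon, turning phenoxy into 3-methoxyphenoxy. For the measured compounds named here, no two measured compounds differ in one place only, so the data offer no direct guide to this change. The expected step of no change at the digits printed from compound 2 to compound 3 (within the scatter) is estimated to stay within the scatter, with neither direction favoured. For compound 3 the estimated value is 0.4 ug/mL (expected range 0.1 ug/mL to 1.5 ug/mL).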

Compound 3, half-maximal inhibitory concentration: 1.5 ug/mL
Beside the measured number, compound 3's estimate is 3.8-fold (0.57 log units) below it; the range from low to high includes it.
By their numbers in this assay, from the lowest: compound 2; then compound 3; then compound 1.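

Placing methoxy on the phenoxy group, which turns it into 3-methoxyphenoxy, brings in this assay a 3.8-fold higher number from compound 2 to compound 3 (0.57 log units; beyond the scatter) and so moves the read-out towards weaker inhibition. This position is therefore not indifferent to substitution: a single methoxy produces a modest step beyond the scatter. Nothing measured here accounts for this step. As far as these compounds go, it remains open whether a hydroxyl group or a chlorine atom at this position would give a similar step. From the compounds shown here alone, it is also open whether methoxy elsewhere on that ring would do so.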